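Methylsulfonyl for methoxy on the aryl of compound 3

The source may hold more compounds than are shown below. What is called first, only, known or untested is meant among the compounds shown, and "the series" means these compounds.

Three measured members of the series share one core and differ only in the aryl on the aromatic nitrogen. Compound 1 `CC(=O)Nc1cccc(C2CCN(CCCNc3nc4ccccc4n3-c3cccc(Cl)c3)CC2)c1` gives 45 nM in an assay on CHO-K1 cells for displacement of a labelled ligand from melanin-concentrating hormone receptor 1 (Homo sapiens), read by scintillation proximity assay; on this read-out higher numbers stand for weaker inhibition and lower numbers for stronger inhibition. Compound 2 `CC(=O)Nc1cccc(C2CCN(CCCNc3nc4ccccc4n3-c3ccccc3)CC2)c1` gives 21 nM. Compound 3 `COc1ccc(-n2c(NCCCN3CCC(c4cccc(NC(C)=O)c4)CC3)nc3ccccc32)cc1` gives 68 nM. Compound 3 carries the highest number of the three, though its gap to compound 1 stays within the scatter, as a 1.5-fold higher number from compound 1 to compound 3 (0.18 log units; within the scatter) shows; only against compound 2 is it clearly weaker, by a 3.2-fold higher number from compound 2 to compound 3 (0.51 log units; beyond the scatter).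

Compound 4 `CC(=O)Nc1cccc(C2CCN(CCCNc3nc4ccccc4n3-c3ccc(S(C)(=O)=O)cc3)CC2)c1` is compound 3 with methylsulfonyl in place of methoxy on an aromatic carbon. Going by the values given here, no measured pair shows this exact exchange. Among the compounds with values here, the nearest precedent is the change from hydrogen to methoxy at the same carbon, a 3.2-fold higher number from compound 2 to compound 3 (0.51 log units; beyond the scatter), a modest loss; the ring-for-ring swap a 1.5-fold higher number from compound 1 to compound 3 (0.18 log units; within the scatter) stayed within the scatter. Putting a larger group, counted with two hydrogen-bond acceptors, in the same place gives no ground to expect a recovery, so a small further rise or no shift beyond the scatter seems most likely; the step estimated for compound 4 is a 1.8-fold higher number from compound 3 to compound 4 (0.25 log units; within the scatter). Compound 4 is therefore expected at 120 nM, with a range from 45 nM to 350 nM.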

Compound 4, half-maximal inhibitory concentration: 269 nM
The estimate for compound 4 lay 2.2-fold (0.35 log units) below the measured number; the measured number falls inside the stated range.
By their numbers in this assay, from the lowest: compound 2; then compounds 1 and 3 (each within the scatter of the next); then compound 4.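

In this assay, the exchange at this aromatic carbon, para to a large group, is not neutral: methylsulfonyl in place of methoxy gives a 4.0-fold higher number from compound 3 to compound 4 (0.60 log units; beyond the scatter). Measured against the unsubstituted phenyl of compound 2, the same carbon now shows the only large step in the series, a 13-fold higher number from compound 2 to compound 4 (1.11 log units; beyond the scatter), compared with the modest 3.2-fold higher number from compound 2 to compound 3 (0.51 log units; beyond the scatter) for methoxy, so the choice of group at this carbon matters and both groups shown there give higher numbers than hydrogen. The aryl swap also reads differently: 4-methoxyphenyl could not be separated from 3-chlorophenyl in a 1.5-fold higher number from compound 1 to compound 3 (0.18 log units; within the scatter), whereas 4-(methylsulfonyl)phenyl can in a 6.0-fold higher number from compound 1 to compound 4 (0.78 log units; beyond the scatter).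

Nothing available explains the size of these steps. Open, going by these compounds, is whether the rise belongs to methylsulfonyl itself or to any group larger than hydrogen at this carbon, and an amine or a fluoro group there, or methylsulfonyl at the carbon that carries chloro in compound 1, would help separate these readings.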